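The source may report more compounds than this note shows. Statements on the series, on what has been measured and on what is new or still open speak of the compounds shown alone.

compound 1 `Cc1ccc(-c2nn(-c3ccccc3)cc2-c2nc3ccccc3n2S(=O)(=O)c2ccccc2)cc1` gives 960 nM
compound 2 `COc1ccc(S(=O)(=O)n2c(-c3cn(-c4ccccc4)nc3-c3ccc(F)cc3)nc3ccccc32)cc1` gives 470 nM

In a functional assay on HepG2 cells (Homo sapiens) for antiproliferative activity, read by MTT assay, with a stated time of 24 h (on this read-out lower numbers stand for stronger inhibition and higher numbers for weaker inhibition), compound 2 gives 470 nM as the lower of the two numbers, and compound 1 gives 960 nM as the higher one, a gap beyond the usual scatter. Compound 3 `O=S(=O)(c1ccc(Cl)cc1)n1c(-c2cn(-c3ccccc3)nc2-c2ccc(F)cc2)nc2ccccc21` carries chloro in place of methoxy on an aromatic carbon, para to a large group, turning 4-methoxyphenyl to 4-chlorophenyl: chloro in place of methoxy on an aromatic carbon is the whole change. For the measured compounds named here, no pair of measured compounds shows this change alone, so the expectation in this assay is no step beyond the scatter, in either direction. The estimated move is a 1.1-fold higher number from compound 2 to compound 3 (0.03 log units; within the scatter) and no more. Compound 3 is expected at 500 nM on this estimate, with a likely range from 180 nM to 1400 nM in repeated measurements.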

Compound 3, half-maximal inhibitory concentration: 4230 nM
Estimate against measurement, compound 3: 8.5-fold (0.93 log units) below; the measured number lies above the stated range.
By their numbers in this assay, from the lowest: compound 2; then compound 1; then compound 3.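

In this assay, the exchange of methoxy for chloro on the ring of the (4-methoxyphenyl)sulfonyl group gives a 9.0-fold higher number from compound 2 to compound 3 (0.95 log units; beyond the scatter) and so shows that this position is not indifferent to its substituent. For the compounds shown here, compound 1 and compound 2 differ in more than one place, so only this pair isolates a change here. No measurement at hand accounts for the rise. Going by these compounds alone, only two groups at this position can be compared directly. From the compounds shown here alone, whether an amine or a hydroxyl group here would stay near compound 2 or rise towards compound 3 remains open.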